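Macrocycle and open-chain pairs: methoxy to fluoro

The compounds below may be only part of what the source reports. "The series", "measured", "known", "first", "only" and "open" are said of these compounds alone.

Measured so far in a functional assay on A549 cells (Homo sapiens) for inhibition, read by colorimetric assay and MTT assay, with a stated time of 72 h; a higher number here means a weaker inhibitor, a lower number a stronger inhibitor:
compound 1 `COc1ccc2c(c1)-c1cnc(n1C)OCCCCCCCCO2` gives 40000 nM
compound 2 `Cn1c2cnc1OCCCCCCCCOc1ccc(F)cc1-2` gives 58000 nM
compound 3 `C=CCCCCOc1ccc(OC)cc1-c1cnc(OCCC=C)n1C` gives 43000 nM

Compound 1 and compound 2 share a closed core and differ by fluoro in place of methoxy on an aromatic carbon; the step is a 1.5-fold higher number from compound 1 to compound 2 (0.16 log units; within the scatter). Compound 3 carries the same pair of substituents on an open core; the difference between the two cores is not broken down here. Compound 4 `C=CCCCCOc1ccc(F)cc1-c1cnc(OCCC=C)n1C` is the open-chain counterpart of compound 2 and differs from compound 3 by fluoro in place of methoxy on an aromatic carbon. The change is the same kind of change as that from compound 1 to compound 2, not the same: there the place is part of a fused or bridged system of three rings, meta to a fused ring and para to a fused ring, whereas here it is meta to a large group and para to a (hex-5-en-1-yl)oxy group.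

For compound 4 in this assay a step of a 1.3-fold higher number from compound 3 to compound 4 (0.13 log units; within the scatter) is expected, resting on the step from compound 1 to compound 2 of a 1.5-fold higher number from compound 1 to compound 2 (0.16 log units; within the scatter) for the same kind of change. The value of compound 4 is estimated at 58000 nM, with a range of 30000 nM to 120000 nM. The measurement will show whether the open core behaves like the closed one.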

Compound 4, half-maximal inhibitory concentration: 61000 nM
Beside the measured number, compound 4's estimate is 1.1-fold (0.02 log units) below it; the measured number falls inside the stated range.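

In this assay, fluoro in place of methoxy on the open core gives a 1.4-fold higher number from compound 3 to compound 4 (0.15 log units; within the scatter). Set beside the same change on the closed core, the two steps agree: the same change on two cores in this assay, a 1.5-fold higher number (0.16 log units; within the scatter) from compound 1 to compound 2 and a 1.4-fold higher number (0.15 log units; within the scatter) from compound 3 to compound 4, 1.0-fold (0.01 log units) apart, within the scatter of two such steps
Going by these compounds alone, since each step lies within the scatter, this shows only that the change leaves the number within the scatter on both cores; it does not show that fluoro and methoxy truly differ here, nor that a step of real size would carry from one core to the other.

Still open, as far as these compounds go, is whether an amine or a carboxylic acid on that aromatic carbon would give a step beyond the scatter on either core. Also open, from the compounds shown here alone, is whether a shorter or longer chain would alter how the change carries across the cores.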